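Compound 1 to compound 4: imidazole replaced by indole carboxylate

The source may report more compounds than this note shows. Statements on the series, on what has been measured and on what is new or still open speak of the compounds shown alone.

Compound 1 `OC[C@@H](O[C@H]1CCCN(Cc2ncc[nH]2)[C@H]1c1ccccc1)c1cc(Cl)cc(Cl)c1` is the reference of this set. In an assay on HEK293 cells for activation of cGMP-dependent protein kinase 1 (Homo sapiens), read by HTRF, with a stated time of 3 h (on this read-out higher numbers stand for an effect only at larger amounts of compound and lower numbers for an effect already at smaller amounts), compound 1 gives 8800 nM. Compound 2 `COC(=O)Nn1c(C[C@H]2CCC[C@H](OCc3cc(C(F)(F)F)cc(C(F)(F)F)c3)[C@@H]2c2ccccc2)n[nH]c1=O` gives 12000 nM in this assay. Among the two numbers, compound 1 has the lower one, and compound 2, its nearest neighbour, lies within the scatter of it, so no order between them is claimed. Compound 3 `Clc1cc(Cl)cc(CO[C@H]2CCCN(Cc3ncc[nH]3)[C@H]2c2ccccc2)c1` reaches only a limit of this assay, > 164000 nM, not a number. Among the compounds with values here, the single measured step of the set is an at least 18-fold higher number from compound 1 to compound 3 (1.27 log units; beyond the scatter), and its size follows from the limit of > 164000 nM in this assay, at which 1 of the 3 values shown sits, at which compound 3 sits.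

Compound 4 `O=C(O)c1ccc2c(CN3CCC[C@H](O[C@H](CO)c4cc(Cl)cc(Cl)c4)[C@@H]3c3ccccc3)c[nH]c2c1` differs from compound 1 by 6-carboxy-1H-indol-3-yl in place of 1H-imidazol-2-yl on a saturated chain carbon bound to an amine nitrogen in a ring. Within the data shown here, no measured step of the set touches this position: the one step known, from compound 1 to compound 3, concerns the hydroxymethyl, which compound 4 keeps unchanged. For the exchange of the group on the chain carbon bound to the ring amine nitrogen the set holds no comparison, so no step beyond the scatter is expected in this assay in either direction, with wide uncertainty. Compound 4 is therefore estimated at 8800 nM, between 1500 nM and 50000 nM. The expected step is no change at the digits printed from compound 1 to compound 4 (within the scatter).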

Compound 4, half-maximal effective concentration: 140000 nM
Estimate against measurement, compound 4: 16-fold (1.20 log units) below; the whole stated range lies below it.
By their numbers in this assay, from the lowest: compounds 1 and 2 (each within the scatter of the next); then compound 4. At a limit, above all of these: compound 3.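

In this assay, the group on the saturated chain carbon bound to an amine nitrogen in a ring proves to be a sensitive place, with a 16-fold higher number from compound 1 to compound 4 (1.20 log units; beyond the scatter). The core of compound 1 therefore has two places where a single exchange raises the number beyond the scatter: this one and the hydroxymethyl, which the earlier comparison had already covered, and 1H-imidazol-2-yl is not freely exchanged for the larger 6-carboxy-1H-indol-3-yl, which brings a second aromatic ring and a carboxylic acid. Compound 4 still gives a number rather than a limit, so this step can be read in full, though the value lies close to the top of what the series shows: the limit of > 164000 nM in this assay, at which 1 of the 4 values shown sits.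

The exchange changes the ring and adds the carboxylic acid in one move, so the step cannot be assigned to either part; a plain 1H-indol-3-yl, or an imidazole carrying a carboxylic acid, would separate the two. On these data alone, it also stays open whether any group at this place gives a lower number than compound 1, for instance a simple amine on a longer chain.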